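Varying the basic amine on a coumarin ether side chain

The compounds below may be only part of what the source reports. "The series", "measured", "known", "first", "only" and "open" are said of these compounds alone.

Measured in a functional assay on SK-BR-3 cells (Homo sapiens) for antiproliferative activity; a higher number here means a weaker inhibitor, a lower number a stronger inhibitor:
compound 1 `CC(C)=CCc1cc(C(=O)Nc2cc3ccc(OCC4CCCN(C)C4)c(C)c3oc2=O)ccc1O` — 1300 nM
compound 2 `CC(C)=CCc1cc(C(=O)Nc2cc3ccc(OCCCN(C(C)C)C(C)C)c(C)c3oc2=O)ccc1O` — 1600 nM

Compound 2 sits alongside compound 1 within the scatter, as a 1.2-fold higher number from compound 1 to compound 2 (0.09 log units; within the scatter) shows. Compound 3 `CC(C)=CCc1cc(C(=O)Nc2cc3ccc(OCCCNC4CCCCC4)c(C)c3oc2=O)ccc1O` is the next member of the series. cyclohexylamino in place of diisopropylamino on a saturated chain carbon, three bonds along the chain from an oxygen on an aromatic ring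

Going by the values given here, the only measured step that bears on this change is a 1.2-fold higher number from compound 1 to compound 2 (0.09 log units; within the scatter), where another exchange of the basic amine on the same ether chain left the number essentially unmoved. On that basis, the change to compound 3 is expected to give a 1.1-fold lower number from compound 2 to compound 3 (0.03 log units; within the scatter). Compound 3 is therefore estimated at 1500 nM, within a range of 600 nM to 4000 nM.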

Compound 3, half-maximal inhibitory concentration: 660 nM
Beside the measured number, compound 3's estimate is 2.3-fold (0.36 log units) above it; measured number inside the range.
By their numbers in this assay, from the lowest: compounds 3, 1 and 2 (each within the scatter of the next, the first and the last beyond it).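

In this assay, going by these compounds alone, the change on the saturated chain carbon, three bonds along the chain from an oxygen on an aromatic ring, moves the number beyond the scatter for the first time, with a 2.4-fold lower number from compound 2 to compound 3 (0.38 log units; beyond the scatter). Cyclohexylamino brings a ring and a hydrogen-bond donor that diisopropylamino lacks, yet the comparison with the other side chain stays within the scatter, with a 2.0-fold lower number from compound 1 to compound 3 (0.29 log units; within the scatter). No evidence is available on what lies behind this step.

Whether the ring or the donor accounts for the step remains open. An open-chain isopropylamino group at this place would separate the two.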